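The source may hold more compounds than are shown below. What is called first, only, known or untested is meant among the compounds shown, and "the series" means these compounds.

Measured compounds:
Compound 1, `O=C1C=CCC(/C=C/c2ccc(C(F)(F)F)cc2)O1`: 69.7 uM
Compound 2, `COc1ccc(/C=C/C2CC=CC(=O)O2)cc1`: 58.8 uM
Compound 3, `O=C1C=CCC(/C=C/c2ccc(C(F)(F)F)cc2)N1`: 174 uM

All three were run in an ADME assay on HaCaT cells (Homo sapiens) for inhibition, read by sulforhodamine B assay, with a stated time of 48 h; a higher number here means a weaker inhibitor of growth, a lower number a stronger inhibitor of growth. Compound 3 stands at the highest number of the three; how its core differs from the core of compound 1 is not broken down here. Between compound 1 and compound 2 one change is made, (methoxy in place of trifluoromethyl on an aromatic carbon), and it gave a 1.2-fold lower number from compound 1 to compound 2 (0.07 log units; within the scatter).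

Compound 4, `COc1ccc(/C=C/C2CC=CC(=O)N2)cc1`, is not yet measured. It differs from compound 3 by methoxy in place of trifluoromethyl on an aromatic carbon, the same change as that from compound 1 to compound 2, at the same place. Resting on compound 3 at 174 uM and on the small step of a 1.2-fold lower number from compound 1 to compound 2 (0.07 log units; within the scatter), a step of similar size, a 1.2-fold lower number from compound 3 to compound 4 (0.06 log units; within the scatter), is expected, so compound 4 is estimated at 150 uM in this assay, with a likely range from 75 uM to 300 uM.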

Compound 4, concentration for growth inhibition (reported as GI): > 1090 uM
Compound 4: a limit, no number (the forecaster's own chance of this, stated with the estimate: 20%); middle value at least 7.2-fold (0.86 log units) away from the limit.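

In this assay compound 4 gives > 1090 uM as a limit of the assay, not a number. Methoxy in place of trifluoromethyl gave an at least 6.2-fold higher number from compound 3 to compound 4 (0.79 log units; beyond the scatter) and so did not carry over from the core of compound 1 to the core of compound 3 as a step of the same size: the same change on two cores in this assay, a 1.2-fold lower number (0.07 log units; within the scatter) from compound 1 to compound 2 and an at least 6.2-fold higher number (0.79 log units; beyond the scatter) from compound 3 to compound 4, at least 7.4-fold (0.87 log units) apart, beyond the scatter of two such steps. Among the compounds shown here, this rests on only two cores and a limit, so it does not show the true size of the step on the core of compound 3, or why the two cores part.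

The compounds shown leave open whether other groups at this place, such as an amine, a nitrile or a carboxylic acid, would also split the two cores. They also leave open whether a longer chain there would do so.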